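This account rests on a few compounds, and the source may have more. Where it says the series, first, only, none or still open, it means among the compounds named here.

Compounds measured in an assay on HEK293 cells for agonist activity at Toll-like receptor 8 (Homo sapiens), read by spectrophotometry; on this read-out lower numbers stand for an effect already at smaller amounts and higher numbers for an effect only at larger amounts of compound:
compound 1, `CCCCNc1nc(N)nc(C)c1CC`: 1660 nM
compound 2, `CCCCNc1nc(N)nc(C)c1CCCN(C)C`: 126 nM
compound 3, `CCCCNc1nc(N)nc(C)c1CCC(C)(C)O`: 3140 nM

Compound 3 stands at the highest of the three numbers in this assay. Its nearest neighbour is reached by a 1.9-fold higher number from compound 1 to compound 3 (0.28 log units; within the scatter), and its furthest by a 25-fold higher number from compound 2 to compound 3 (1.40 log units; beyond the scatter).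

Compound 4, `CCCCNc1nc(N)nc(C)c1C#C[Si](C)(C)C`, has not yet been measured. It differs from compound 3 in one place: a group of 6 heavy atoms (5 carbon, 1 silicon; no ring) in place of a group of 6 heavy atoms (5 carbon, 1 oxygen; no ring), on an aromatic carbon. For the measured compounds named here, no measured step covers an alkyne or a silicon group, so none bears on this change directly. The steps that exist tell what the chain substituents did: a 13-fold lower number from compound 1 to compound 2 (1.12 log units; beyond the scatter) is large, while a 1.9-fold higher number from compound 1 to compound 3 (0.28 log units; within the scatter) stays within the scatter. Compound 4 carries neither the dimethylamino group of compound 2 nor the hydroxy group of compound 3, so it is expected to land near compound 1 and compound 3 rather than near compound 2. The expected step is a 1.3-fold lower number from compound 3 to compound 4 (0.10 log units; within the scatter), a change not beyond the scatter. Compound 4 is therefore estimated at 2500 nM, with a range from 600 nM to 10000 nM.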

Compound 4, half-maximal effective concentration: 9240 nM
Estimate against measurement, compound 4: 3.7-fold (0.57 log units) below, and the stated range covers the measured number.
By their numbers in this assay, from the lowest: compound 2; then compounds 1 and 3 (each within the scatter of the next); then compound 4.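

At this position, on the aromatic carbon ortho to a butylamino group, this assay does not treat every group without the dimethylamino function alike: the silicon-bearing alkyne gives a 5.6-fold higher number from compound 1 to compound 4 (0.75 log units; beyond the scatter) and also a 2.9-fold higher number from compound 3 to compound 4 (0.47 log units; beyond the scatter) in place of 3-hydroxy-3-methylbutyl. For the compounds shown here, compound 3 had stayed within the scatter of compound 1, so compound 4 is the first to show a rise beyond the scatter from that pair. The position now spans a 73-fold higher number from compound 2 to compound 4 (1.87 log units; beyond the scatter) as its full range, but no measurement here accounts for the rise.

Compound 4 changes the triple bond and the silicon together, so their shares cannot be separated. A plain ethynyl group, a tert-butyl alkyne, or a primary amine on the saturated chain would each test a part of this that the four compounds leave open.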